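Imidazolyl Substituent on the Second Methyl of Compound 1

The compounds below may be only part of what the source reports. "The series", "measured", "known", "first", "only" and "open" are said of these compounds alone.

Compound 1 `Cc1c(C)n(CCNS(=O)(=O)c2ccc(F)cc2)c2ccc(CCC(=O)O)cc12` is the parent of this small series. In a functional assay on aorta for antagonist activity at thromboxane A2 receptor (Rattus norvegicus) (a higher number here means weaker binding, a lower number tighter binding), compound 1 gives 2.51 nM, the highest of the three numbers recorded. Two measured analogues build on its core. Compound 2 `Cc1c(Cn2ccnc2)c2cc(CCC(=O)O)ccc2n1CCNS(=O)(=O)c1ccc(F)cc1` gives 1.59 nM, and compound 3 `Cc1c(Cc2cccnc2)c2cc(CCC(=O)O)ccc2n1CCNS(=O)(=O)c1ccc(F)cc1` gives 0.692 nM. The step of a 1.6-fold lower number from compound 1 to compound 2 (0.20 log units; within the scatter) lies within the scatter, the step of a 3.6-fold lower number from compound 1 to compound 3 (0.56 log units; beyond the scatter) is a modest gain, and the step of a 2.3-fold lower number from compound 2 to compound 3 (0.36 log units; beyond the scatter) is again modest.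

Compound 4 `Cc1c(Cn2ccnc2)n(CCNS(=O)(=O)c2ccc(F)cc2)c2ccc(CCC(=O)O)cc12` has not yet been measured. Compared with compound 1 it carries 1H-imidazol-1-yl in place of hydrogen on a saturated chain carbon bound to an aromatic carbon. Going by the values given here, this is the same kind of change as the one leading to compound 2, yet compound 4 is a distinct compound, not compound 2 itself. Among the compounds with values here, the only step that bears on it, a 1.6-fold lower number from compound 1 to compound 2 (0.20 log units; within the scatter), stayed within the scatter. The expectation is therefore a small change at most, a 1.3-fold lower number from compound 1 to compound 4 (0.10 log units; within the scatter), in this assay. Compound 4 is estimated at 2 nM, with a likely range from 0.8 nM to 5 nM.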

Compound 4, dissociation constant: 138 nM
Estimate against measurement, compound 4: 69-fold (1.84 log units) below; the whole stated range lies below it.
By their numbers in this assay, from the lowest: compound 3; then compounds 2 and 1 (each within the scatter of the next); then compound 4.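

In this assay the change from methyl to (1H-imidazol-1-yl)methyl gives a 55-fold higher number from compound 1 to compound 4 (1.74 log units; beyond the scatter) when made on this methyl group, so adding this group to the core of compound 1 is not harmless at every site. The same change on the other methyl group gave only a 1.6-fold lower number from compound 1 to compound 2 (0.20 log units; within the scatter), which shows that the two methyl groups of compound 1 are not interchangeable and that the outcome depends on which one carries the imidazolyl group. Nothing in the data shown explains this difference.

Going by these compounds, it remains open whether the loss belongs to the imidazolyl group itself or would follow any larger group placed here. A phenyl group, a hydroxyl group or a longer chain on this methyl would help separate those two readings, as would the pyridin-3-yl group, which on the other methyl group gave a 3.6-fold lower number from compound 1 to compound 3 (0.56 log units; beyond the scatter) in that comparison.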